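One More Carbon on the Alkyl Chain

The compounds below may be only part of what the source reports. "The series", "measured", "known", "first", "only" and "open" are said of these compounds alone.

Measured so far in a functional assay on HCT-116 cells (Homo sapiens) for antiproliferative activity, read by MTT assay, with a stated time of 48 h; on this read-out higher numbers stand for weaker inhibition and lower numbers for stronger inhibition:
- compound 1 (`CCCCC(CCO)n1cnc2c(Cl)nc(Cl)nc21`): 15500 nM
- compound 2 (`CCCCCCCC(CCO)n1cnc2c(Cl)nc(F)nc21`): 17600 nM
- compound 3 (`CCCCCCCC(CCO)n1cnc2c(Cl)nc(Cl)nc21`): 12800 nM

Compound 3 stands level with the other two compounds, as its two measured steps show. One is a 1.2-fold lower number from compound 1 to compound 3 (0.08 log units; within the scatter) and the other is a 1.4-fold lower number from compound 2 to compound 3 (0.14 log units; within the scatter), so neither separates compound 3 from its neighbour.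

The next compound is compound 4 (`CCCCCCCCC(CCO)n1cnc2c(Cl)nc(Cl)nc21`). It differs from compound 3 by methyl in place of hydrogen on a saturated chain carbon, eight bonds along the chain from an aromatic nitrogen. The chain simply grows at its far end, and the rest of the molecule stays the same.

The halogen step from compound 2 does not bear on this change, since the halogens stay as they are. The step from compound 1 does, as it extends the same chain by more than the new methyl does. Even that larger extension gave only a 1.2-fold lower number from compound 1 to compound 3 (0.08 log units; within the scatter), so no step beyond the scatter is expected here in this assay. This rests on a single chain step, so it is a modest guide.

The expected step is a 1.1-fold lower number from compound 3 to compound 4 (0.03 log units; within the scatter) and it should be read as an estimate. For compound 4 the estimated value is 12000 nM, with an expected range from 6500 nM to 22000 nM as the likely span.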

Compound 4, half-maximal inhibitory concentration: 22200 nM
Beside the measured number, compound 4's estimate is 1.9-fold (0.27 log units) below it; the whole stated range lies below it.
By their numbers in this assay, from the lowest: compounds 3, 1, 2 and 4 (each within the scatter of the next).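

Methyl in place of hydrogen on a saturated chain carbon, eight bonds along the chain from an aromatic nitrogen, gives in this assay a 1.7-fold higher number from compound 3 to compound 4 (0.24 log units; within the scatter) and so stays within the usual scatter of repeated measurements. The full extension from the shortest chain shown gives a 1.4-fold higher number from compound 1 to compound 4 (0.16 log units; within the scatter) and also stays within that scatter. The chain now reaches further than in the earlier compounds, yet the three chain lengths that share both halogens still cannot be put in any order in this read-out, and nothing available offers an explanation for this result.

On these data alone, whether a still longer chain would finally produce a step beyond the scatter remains open. So does the question of whether an amine or a carboxylic acid, placed on a saturated chain carbon eight bonds along the chain from an aromatic nitrogen, would give a different answer from the plain methyl.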